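The source may hold more compounds than are shown below. What is called first, only, known or untested is meant among the compounds shown, and "the series" means these compounds.

Of the compounds shown here, three sharing one core have been tested in an ADME assay on HepG2 cells (Homo sapiens) for inhibition, with a stated time of 48 h; on this read-out higher numbers stand for an effect only at larger amounts of compound and lower numbers for an effect already at smaller amounts. Compound 1 `CC(C(=O)N1C[C@H]2CCC[C@H]2C1)N1CCN(S(=O)(=O)c2ccc(C(C)(C)C)cc2)CC1` gives in this assay only a limit, > 40000 nM. Compound 2 `CC(C(=O)N1CCCCCC1)N1CCN(S(=O)(=O)c2ccc(C(C)(C)C)cc2)CC1` likewise gives in this assay only a limit, > 40000 nM. Compound 3 `CC(C(=O)N1CCC(F)(F)CC1)N1CCN(S(=O)(=O)c2ccc(C(C)(C)C)cc2)CC1` also returns in this assay only a limit, > 40000 nM. Compound 3 thus stands where every measured compound stands, at the limit of > 40000 nM in this assay, at which 3 of the 3 values shown sit. The steps among the three, a step that the two limits leave unreadable from compound 1 to compound 2, a step that the two limits leave unreadable from compound 1 to compound 3 and a step that the two limits leave unreadable from compound 2 to compound 3, cannot be read in size; both ends of each sit at the limit. Compound 4 `CC1CCN(C(=O)C(C)N2CCN(S(=O)(=O)c3ccc(C(C)(C)C)cc3)CC2)CC1` differs from compound 3 by 4-methylpiperidin-1-yl in place of 4,4-difluoropiperidin-1-yl on a carbonyl carbon. The measured steps that bear on this change are all exchanges of the ring on the carbonyl carbon, and none of them produced an effect the assay could register. The expected step is a step that the limit leaves unreadable from compound 3 to compound 4, nothing beyond the scatter. Compound 4 is estimated at 45000 nM, with a range from 20000 nM to 100000 nM. Most likely this assay will again report only a limit for compound 4.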

Compound 4, half-maximal effective concentration: > 40000 nM
Compound 4: a limit, no number (the forecaster's own chance of this, stated with the estimate: 85%); the middle value lies beyond the limit too.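

In this assay compound 4 gives only a limit, > 40000 nM. The steps linking it to compound 1, compound 2 and compound 3 therefore cannot be read in size. The compounds shown leave open at what concentration any of them would show an effect, and how the groups on the carbonyl carbon would rank.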